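Changing the Aryl Group on a Sulfonamide Nitrogen

The compounds below may be only part of what the source reports. "The series", "measured", "known", "first", "only" and "open" are said of these compounds alone.

Of the compounds shown here, three with a shared core have been measured in a functional assay on HT-29 cells (Homo sapiens) for antiproliferative activity, read by sulforhodamine B assay, with a stated time of 48 h; on this read-out lower numbers stand for stronger inhibition and higher numbers for weaker inhibition. Compound 1 `CCc1ccccc1NS(=O)(=O)c1ccc(N2CCNC2=O)cc1` gives 240 nM, compound 2 `O=C1NCCN1c1ccc(S(=O)(=O)Nc2cccc(Br)c2)cc1` gives 77 nM and compound 3 `O=C1NCCN1c1ccc(S(=O)(=O)Nc2ccc(Cl)cc2)cc1` gives 220 nM. Compound 3 cannot be told apart from compound 1, and both numbers stand above that of compound 2.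

Compound 4 `Cc1cccc(NS(=O)(=O)c2ccc(N3CCNC3=O)cc2)c1C` has not yet been measured. It carries 2,3-dimethylphenyl in place of 4-chlorophenyl on a sulfonamide nitrogen.

All three measured steps change the group at this same place, so they give the best available guide to the size of the new step. The data show a 1.1-fold lower number from compound 1 to compound 3 (0.04 log units; within the scatter), so that exchange made no clear difference. The two larger steps, a 3.1-fold lower number from compound 1 to compound 2 (0.49 log units; beyond the scatter) and a 2.9-fold higher number from compound 2 to compound 3 (0.46 log units; beyond the scatter), are modest, and both involve the 3-bromophenyl group of compound 2, which compound 4 does not carry. Among the measured compounds shown here, no measured compound carries 2,3-dimethylphenyl, so the direction remains uncertain.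

The expected result is a 1.5-fold lower number from compound 3 to compound 4 (0.17 log units; within the scatter), which means no clear change. For compound 4, the estimated value in this assay is 150 nM, with an expected range from 60 nM to 380 nM.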

Compound 4, half-maximal inhibitory concentration: 190 nM
For compound 4 the middle estimate is 1.3-fold (0.10 log units) below the measured one; low and high end bracket the measured number.
By their numbers in this assay, from the lowest: compound 2; then compounds 4, 3 and 1 (each within the scatter of the next).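

In this assay, the new group leaves the picture at this position unchanged: 2,3-dimethylphenyl on the sulfonamide nitrogen gives a 1.2-fold lower number from compound 3 to compound 4 (0.06 log units; within the scatter) and a 1.3-fold lower number from compound 1 to compound 4 (0.10 log units; within the scatter), so a ring bearing two methyl groups cannot be told apart from the rings of compound 3 or compound 1. Compound 2 now stands apart from three neighbours rather than two, with a 2.5-fold higher number from compound 2 to compound 4 (0.39 log units; beyond the scatter) joining its earlier steps, so among these four compounds only 3-bromophenyl gives a number that clearly differs from the rest, and 2-ethylphenyl, 4-chlorophenyl and 2,3-dimethylphenyl form a single group within the scatter. No measurement is available that accounts for the separate place of compound 2 or for the similarity of the other three.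

From the compounds shown here alone, it remains open whether the lower number of compound 2 belongs to the bromine atom itself or to where that atom sits on the ring. The compounds shown also leave open how this position would respond to an aryl ring carrying an amine or a carboxylic acid, or to a longer chain in place of the ethyl group of compound 1.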